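A few compounds are considered here, and "the series" means these few. Any claim that something is new, unique, unknown or untested is made for them only; others in the source may bear on it.

In a functional assay on MCF7 cells (Homo sapiens) for inhibition, read by CCK-8 assay, with a stated time of 48 h (a higher number here means a weaker inhibitor of growth, a lower number a stronger inhibitor of growth), compound 1 `Cc1cccc(Nc2nc(Nc3ccc(N4CCN(C)CC4)cn3)ncc2Cl)c1` gives 7160 nM and compound 2 `CCc1ccc(Nc2nc(Nc3ccc(N4CCN(C)CC4)cn3)ncc2Cl)cc1` gives 8230 nM. Among the compounds with values here, these two numbers lie within the scatter of each other, so compound 2 stands level with the only other compound measured so far. Compound 3 `COc1ccc(Nc2nc(Nc3ccc(N4CCN(C)CC4)cn3)ncc2Cl)cc1` keeps the shared core and alters one group: methoxy in place of ethyl on an aromatic carbon. This places methoxy in place of ethyl on an aromatic carbon, para to a large group.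

Within the data shown here, only one measured step bears on this change, and it does so indirectly. That step is a 1.1-fold higher number from compound 1 to compound 2 (0.06 log units; within the scatter), with 4-ethylphenyl in place of 3-methylphenyl on a nitrogen on an aromatic ring, and it stays within the scatter. Among the measured compounds shown here, no measured compound carries methoxy, so the data offer no direct reading of this exchange. Given that small step, no shift beyond the scatter is expected in this assay, and neither direction is favoured. Compound 3 is estimated at 7800 nM, with an expected range of 3500 nM to 16000 nM. The expected step, a 1.1-fold lower number from compound 2 to compound 3 (0.02 log units; within the scatter), would stay within the scatter.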

Compound 3, concentration for 50% growth inhibition: 8450 nM
Compound 3: the middle estimate sits 1.1-fold (0.03 log units) below what was measured; low and high end bracket the measured number.
By their numbers in this assay, from the lowest: compounds 1, 2 and 3 (each within the scatter of the next).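

In this assay, methoxy in place of ethyl on an aromatic carbon, para to a large group, gives a step that stays within the scatter (a 1.0-fold higher number from compound 2 to compound 3 (0.01 log units; within the scatter)), so at this place an oxygen and a hydrogen-bond acceptor enter without any readable shift in the number. The comparison with the 3-methylphenyl group of the first compound reads the same way (a 1.2-fold higher number from compound 1 to compound 3 (0.07 log units; within the scatter)), and the three compounds now stand level in this assay, where the earlier pair alone could not show whether a group carrying oxygen would behave like the two carbon-only groups. No measurement given here offers an explanation for this flat result.

From the compounds shown here alone, what remains open is whether any group at this place can move the number beyond the scatter at all, for instance an amine, a carboxylic acid or a longer chain on the same aromatic carbon. Going by these compounds, it is also open whether the level seen here depends on this ring at all, or whether a change elsewhere on the shared core would matter more in this assay.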